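The source may hold more compounds than are shown below. What is called first, only, known or untested is meant among the compounds shown, and "the series" means these compounds.

Compound 1 `Cc1ccccc1N/C(=N\C#N)Nc1ccc(Cl)c(S(=O)(=O)N(C)C)c1O` stands lowest of the two numbers in an assay on CHO cells for displacement of a labelled ligand from C-X-C chemokine receptor type 1 (Homo sapiens) (a lower number here means a stronger inhibitor, a higher number a weaker inhibitor), giving 378 nM. Among the compounds with values here, compound 2 `CN(C)S(=O)(=O)c1c(Cl)ccc(N/C(=N/C#N)Nc2ccccc2F)c1O` gives 1550 nM in this assay, and the step of a 4.1-fold higher number from compound 1 to compound 2 (0.61 log units; beyond the scatter) is the only measured change that bears on the next compound. Compound 3 `CN(C)S(=O)(=O)c1c(Cl)ccc(N/C(=N/C#N)Nc2cccc(Cl)c2F)c1O` differs from compound 1 by 3-chloro-2-fluorophenyl in place of 2-methylphenyl on an amine nitrogen. The entering ring carries the fluorine seen in compound 2 together with a chlorine; on the strength of a 4.1-fold higher number from compound 1 to compound 2 (0.61 log units; beyond the scatter) a higher number than for compound 1 is expected, of roughly that size. The expected step is a 2.9-fold higher number from compound 1 to compound 3 (0.46 log units; beyond the scatter). Compound 3 is estimated at 1100 nM, with a range of 300 nM to 4000 nM.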

Compound 3, half-maximal inhibitory concentration: 6200 nM
Estimate against measurement, compound 3: 5.6-fold (0.75 log units) below; measured number outside the range, above it.
By their numbers in this assay, from the lowest: compound 1; then compound 2; then compound 3.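

In this assay, chloro in place of hydrogen on an aromatic carbon gives a 4.0-fold higher number from compound 2 to compound 3 (0.60 log units; beyond the scatter) and so recovers nothing of the rise already seen with fluoro. Overall, a 16-fold higher number from compound 1 to compound 3 (1.21 log units; beyond the scatter) comes with 3-chloro-2-fluorophenyl in place of 2-methylphenyl on the amine nitrogen, and 2-methylphenyl remains the lowest of the three. Nothing available explains the rise. As far as these compounds go, whether chloro has a similar effect alongside the methyl of 2-methylphenyl remains open. So does the outcome with a methoxy group or bromine on this ring.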